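Removing the N-acyl group from compound 1

The source may report more compounds than this note shows. Statements on the series, on what has been measured and on what is new or still open speak of the compounds shown alone.

Measured compounds:
compound 1 `O=C(Nc1cc(C(F)(F)F)cc(C(F)(F)F)c1)C1CCc2ccccc2N1C(=O)c1ccccc1Cl` 4050 nM
compound 2 `CCCCCCCCC(=O)N1c2ccccc2CCC1C(=O)Nc1ccccc1C(F)(F)F` 7700 nM
compound 3 `CCCCCCCCC(=O)N1c2ccccc2CCC1C(=O)Nc1ccccc1O` 38400 nM

In a functional assay on HCT-15 cells (Homo sapiens) for cytotoxicity, read by sulforhodamine B assay, with a stated time of 72 h (a lower number here means a stronger inhibitor of growth, a higher number a weaker inhibitor of growth), compound 1 has the lowest of the three numbers. Compound 2 sits close to it, within the scatter, so no order between the two can be read. Compound 3 stands furthest away, beyond the scatter.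

Within the data shown here, the only single-point step measured here is a 5.0-fold higher number from compound 2 to compound 3 (0.70 log units; beyond the scatter), which weakened growth inhibition by a modest amount.

Compound 4 `O=C(Nc1cc(C(F)(F)F)cc(C(F)(F)F)c1)C1CCc2ccccc2N1` differs from compound 1 by hydrogen in place of (2-chlorophenyl)carbonyl on a nitrogen on an aromatic ring in a ring. Among the measured compounds shown here, no measured pair shows what happens when this acyl group is taken off the ring nitrogen: compounds 2 and 3 keep a nonanoyl there, and compound 1 keeps the (2-chlorophenyl)carbonyl. The step from compound 2 to compound 3 concerns the other end of the molecule and does not bear on this change. From the compounds shown here alone, every measured compound carries an acyl group on this nitrogen, so its contribution is untested. With the group removed, a weaker inhibitor than compound 1 is expected, but the size of that expected step, a 4.0-fold higher number from compound 1 to compound 4 (0.60 log units; beyond the scatter), is uncertain. Compound 4 is therefore estimated at 16000 nM, with a wide range from 4000 nM to 64000 nM.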

Compound 4, concentration for 50% growth inhibition: 8700 nM
Compound 4: the middle estimate sits 1.8-fold (0.26 log units) above what was measured; the measured number falls inside the stated range.
By their numbers in this assay, from the lowest: compounds 1, 2 and 4 (each within the scatter of the next, the first and the last beyond it); then compound 3.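

In this assay, taking the (2-chlorophenyl)carbonyl off the ring nitrogen gives a 2.1-fold higher number from compound 1 to compound 4 (0.33 log units; beyond the scatter), so the change is real but modest. Among these compounds, this is the first direct look at this position: a group of nine heavy atoms, including an aromatic ring and a carbonyl, can be replaced by a single hydrogen and growth inhibition remains, so this acyl group is not essential for the activity of compound 1, though it does add a little to it. No measurement shown here explains why losing so large a group changes the number so little.

The compounds shown leave open how a small acetyl group or a plain methyl on this nitrogen would compare with hydrogen and with (2-chlorophenyl)carbonyl, and whether the chlorine on the departing group plays any part in the difference. Among the compounds shown here, it also remains unknown whether removing the nonanoyl from compound 2 or compound 3 would give a similarly modest step, since the one step at this position was taken with a single group at the other end of the molecule.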